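The source may report more compounds than this note shows. Statements on the series, on what has been measured and on what is new or still open speak of the compounds shown alone.

Compound 1 (`Nc1cccc(Nc2nc3ccccc3nc2S(=O)(=O)c2ccc(Br)cc2)c1`): 3280 nM
Compound 2 (`O=S(=O)(c1ccc(Br)cc1)c1nc2ccccc2nc1Nc1cccc(O)c1`): 540 nM
Compound 3 (`O=S(=O)(c1ccc(Br)cc1)c1nc2ccccc2nc1Nc1ccc(Cl)cc1`): 10600 nM

In a functional assay on HCT-116 cells (Homo sapiens) for cytotoxicity, read by MTT assay, with a stated time of 72 h (on this read-out higher numbers stand for weaker inhibition and lower numbers for stronger inhibition), compound 1 holds the middle place of the three, with a higher number than compound 2 and a lower number than compound 3. Compound 4 (`Nc1cccc(Nc2nc3ccccc3nc2S(=O)(=O)c2ccc(F)cc2)c1`) has not yet been measured. It departs from compound 1 in one place (fluoro in place of bromo on an aromatic carbon), with fluoro in place of bromo on an aromatic carbon, para to a large group. Going by the values given here, no measured step touches that place. All three steps change the group on the nitrogen instead: the modest 6.1-fold lower number from compound 1 to compound 2 (0.78 log units; beyond the scatter) and the modest 3.2-fold higher number from compound 1 to compound 3 (0.51 log units; beyond the scatter) as well as the large 20-fold higher number from compound 2 to compound 3 (1.29 log units; beyond the scatter). They show that the number moves with that group but say nothing about the halogen. No step beyond the scatter is therefore expected in this assay, and no direction is favoured, although the range stays wide. The expected change is small (a 1.0-fold higher number from compound 1 to compound 4 (0.00 log units; within the scatter)). For compound 4 the estimated value is 3300 nM (expected range 1200 nM to 9000 nM).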

Compound 4, half-maximal inhibitory concentration: 6790 nM
Beside the measured number, compound 4's estimate is 2.1-fold (0.31 log units) below it; the range from low to high includes it.
By their numbers in this assay, from the lowest: compound 2; then compound 1; then compounds 4 and 3 (each within the scatter of the next).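

Going by these compounds alone, the earlier compounds changed only the group on the nitrogen, so this is the first reading of the halogen on an aromatic carbon, para to a large group. In this assay, replacing 4-bromophenyl with 4-fluorophenyl gives a 2.1-fold higher number from compound 1 to compound 4 (0.32 log units; beyond the scatter), a modest step beyond the scatter, which shows that the number also responds to this position while the 3-aminophenyl group stays fixed. Nothing available explains the direction of this step.

The compounds shown leave open how chloro, methoxy or a carboxylic acid would read at this position, since bromo and fluoro are the only groups seen there. They also leave open whether the same halogen change would give a similar step with the 3-hydroxyphenyl group of compound 2 or the 4-chlorophenyl group of compound 3.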